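A few compounds are considered here, and "the series" means these few. Any claim that something is new, unique, unknown or untested is made for them only; others in the source may bear on it.

Compound 3, with the structure `Cc1ccc(S(=O)(=O)N2N=C(c3ccc(N4CCN(C)CC4)cc3)CC2c2ccc(N(C)C)cc2)cc1`, is one of three compounds whose shared core carries a 4-(4-methylpiperazin-1-yl)phenyl group and a 4-(dimethylamino)phenyl group and differs only in the group on the ring nitrogen. In a functional assay on NCI-H1975 cells (Homo sapiens) for inhibition, read by sulforhodamine B assay, tested at 10 uM (on this read-out lower numbers stand for less inhibition and higher numbers for more inhibition at the one concentration tested (going by the name of the read-out)), compound 3 gives 38.1%. This is the second highest of the three numbers: compound 1, with the structure `CN1CCN(c2ccc(C3=NN(C(=O)c4ccc(F)cc4)C(c4ccc(N(C)C)cc4)C3)cc2)CC1`, gives 32.2%, and the step of a number 5.9 percentage points higher from compound 1 to compound 3 (within the scatter) lies within the scatter, whereas compound 2, with the structure `CN1CCN(c2ccc(C3=NN(C(=O)/C=C/c4ccccc4)C(c4ccc(N(C)C)cc4)C3)cc2)CC1`, gives 81%, and the step of a number 42.9 percentage points lower from compound 2 to compound 3 (beyond the scatter) is large.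

Compound 4, with the structure `CN1CCN(c2ccc(C3=NN(S(=O)(=O)c4ccc(OC(F)(F)F)cc4)C(c4ccc(N(C)C)cc4)C3)cc2)CC1`, is not yet measured. It differs from compound 3 in one place: trifluoromethoxy in place of methyl on an aromatic carbon. Going by the values given here, no measured step changes a substituent on that ring while the sulfonyl link is kept; the steps of a number 48.8 percentage points higher from compound 1 to compound 2 (beyond the scatter) and a number 5.9 percentage points higher from compound 1 to compound 3 (within the scatter) replace the whole group on the ring nitrogen and so do not bear on this change directly. With nothing pointing either way, a step within the scatter is expected, a number 0.1 percentage points lower from compound 3 to compound 4 (within the scatter). Compound 4 is therefore estimated at 38%, within a range from 20% to 60%.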

Compound 4, a percentage reported as inhibition, at one concentration (the size of the read-out at that concentration, not a potency): 26.5%
Compound 4: middle estimate off by 11.5 percentage points, on the high side; low and high end bracket the measured number.
By their numbers in this assay, from the lowest: compounds 4, 1 and 3 (each within the scatter of the next, the first and the last beyond it); then compound 2.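

In this assay, trifluoromethoxy in place of methyl on the aromatic ring of the sulfonyl group gives a number 11.6 percentage points lower from compound 3 to compound 4 (beyond the scatter). The earlier steps shown here replaced the whole group on the ring nitrogen, whereas this one shows that the read-out also responds to a substituent at this single position, with the sulfonyl link kept. The data available offer no explanation for why this substituent goes with the lower number.

As far as these compounds go, with one pair at this position, it remains open whether a methoxy group, a chlorine or an amine on the same ring would go with a higher or a lower number than methyl. From the compounds shown here alone, it also remains open whether trifluoromethoxy would shift the number in the same way on the 4-fluorophenyl ring of compound 1, in place of the fluorine.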